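From a Carbamoyl Group to a Benzylsulfonyl Group

The source may report more compounds than this note shows. Statements on the series, on what has been measured and on what is new or still open speak of the compounds shown alone.

Two compounds share one core. Compound 1 `O=C(Oc1ccccc1)N1CCC(CN(Cc2ccc(Cl)cc2)Cc2ccc([N+](=O)[O-])s2)C1` has no reported result: in a functional assay on HEK293 cells for agonist activity at nuclear receptor subfamily 1 group D member 1 (Homo sapiens), read by a luciferase reporter, with a stated time of 24 h (a lower number here means that less compound is needed, a higher number that more compound is needed for the effect), compound 1 gives "not determined" (no result reported). Going by the values given here, compound 2 `O=C(Nc1ccc([N+](=O)[O-])cc1)N1CCC(CN(Cc2ccc(Cl)cc2)Cc2ccc([N+](=O)[O-])s2)C1` was tested in this assay, where compound 2 gives 400 nM; as the only number reported, it is the sole anchor for what follows. Compound 3 `O=[N+]([O-])c1ccc(CN(Cc2ccc(Cl)cc2)CC2CCN(S(=O)(=O)Cc3ccccc3)C2)s1` differs from compound 2 in one place: benzylsulfonyl in place of (4-nitrophenyl)carbamoyl on an amine nitrogen in a ring. Among the compounds with values here, no measured pair in this set shows how such a change plays out, so the expectation rests on compound 2 alone. The leaving group counts one hydrogen-bond donor and three acceptors, the entering group none and two. The expected step is a 2.5-fold higher number from compound 2 to compound 3 (0.40 log units; beyond the scatter) in this assay, modest and towards needing more compound, though it could still fall within the usual scatter. On this basis compound 3 is expected to give about 1000 nM, estimated to lie between 250 nM and 4000 nM.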

Compound 3, half-maximal effective concentration: 630 nM
For compound 3 the middle estimate is 1.6-fold (0.20 log units) above the measured one; measured number inside the range.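

Replacing (4-nitrophenyl)carbamoyl with benzylsulfonyl on the amine nitrogen in the ring gives a 1.6-fold higher number from compound 2 to compound 3 (0.20 log units; within the scatter) in this assay and so leaves the two compounds indistinguishable. This position therefore tolerates a change from a carbamoyl to a sulfonyl link, and a number of this size does not depend on the hydrogen-bond donor of the leaving group or on its nitro group. No measurement shown explains why the two groups give such similar results.

Compound 1 has no result, so steps involving it cannot be read. From the compounds shown here alone, it also remains open whether this nitrogen needs an aromatic ring in its substituent at all, as a small acetyl or methyl group there would test, and whether an amine or a carboxylic acid on the benzyl ring would be accepted.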